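The source may report more compounds than this note shows. Statements on the series, on what has been measured and on what is new or still open speak of the compounds shown alone.

Compound 1, whose structure is `COc1nc(N)nc2c1c(-c1ccccc1)cn2[C@@H]1O[C@H](CO)[C@@H](O)[C@H]1O`, was tested in a functional assay on A549 cells (Homo sapiens), read by MTT assay, with a stated time of 72 h; on this read-out lower numbers stand for stronger inhibition and higher numbers for weaker inhibition. Compound 1 gives > 20000 nM, which is a limit of the assay and not a number. Compound 2, with the structure `C#Cc1cn([C@@H]2O[C@H](CO)[C@@H](O)[C@H]2O)c2nc(N)nc(OC)c12`, differs from compound 1 by ethynyl in place of phenyl on an aromatic carbon. In this assay compound 2 gives > 100000 nM, again a limit rather than a measured number. Because both values are limits, the step that the two limits leave unreadable from compound 1 to compound 2 cannot be read; the two limits involved are the limit of > 100000 nM in this assay, at which 1 of the 3 values shown sits, and (the limit of > 20000 nM in this assay, at which 2 of the 3 values shown sit).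

Compound 3 has the structure `COc1ncnc2c1c(-c1ccccc1)cn2[C@@H]1O[C@H](CO)[C@@H](O)[C@H]1O`. Its core differs from that of compound 1 by hydrogen in place of amino on an aromatic carbon. In this assay compound 3 gives > 20000 nM, which is also a limit.

Compound 4, not yet measured, has the structure `C#Cc1cn([C@@H]2O[C@H](CO)[C@@H](O)[C@H]2O)c2ncnc(OC)c12`. It stands to compound 3 as compound 2 stands to compound 1: the change is ethynyl in place of phenyl on an aromatic carbon. The surroundings are described in nearly the same words, the only difference being that in one case the ring atom bears "a group of 9 heavy atoms" and in the other "a 3,4-dihydroxy-5-(hydroxymethyl)oxolan-2-yl group (9 heavy atoms)", so this is the same kind of change rather than the same one.

Since compound 1, compound 2 and compound 3 all sit at limits in this assay, a limit is expected for compound 4 too, and the step from compound 3 to compound 4 is estimated at a step that the limit leaves unreadable from compound 3 to compound 4. For compound 4 the estimate is 50000 nM, between 20000 nM and 200000 nM.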

Compound 4, half-maximal inhibitory concentration: 8160 nM
Beside the measured number, compound 4's estimate is 6.1-fold (0.79 log units) above it, outside the stated range (below it).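

In this assay, ethynyl in place of phenyl gives an at least 2.4-fold lower number from compound 3 to compound 4 (0.38 log units; beyond the scatter), so on the core without the amino group this change clearly lowers the number, and with ethynyl already in place, hydrogen in place of amino gives an at least 12-fold lower number from compound 2 to compound 4 (1.08 log units; beyond the scatter). As far as these compounds go, the same ethynyl change on the core of compound 1 cannot be read, and neither can hydrogen in place of amino with phenyl in place, because each of those pairs rests on values that are limits of the assay and not numbers, among them this one: the limit of > 20000 nM in this assay, at which 2 of the 4 values shown sit. So the series holds just one readable case of the ethynyl change, and that case does not show that the change carries over to the amino-bearing core, where its size and even its direction remain unknown.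

From the compounds shown here alone, what stays open is whether ethynyl itself matters or whether losing phenyl is enough, a question that hydrogen or methyl on that same aromatic carbon of the core of compound 3 could help to settle. Also open, going by these compounds, is how a longer chain such as propyl, or an amine or a carboxylic acid at that carbon, would read out in this assay.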